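A few compounds are considered here, and "the series" means these few. Any claim that something is new, unique, unknown or untested is made for them only; others in the source may bear on it.

Three compounds built on one shared core were measured in a functional assay on HeLa cells (Homo sapiens) for cytotoxicity, read by MTT assay, with a stated time of 72 h; on this read-out lower numbers stand for stronger inhibition and higher numbers for weaker inhibition. Compound 1 `NS(=O)(=O)c1cc(-c2nnc(CN3CCN(Cc4ccccc4)CC3)o2)c(Cl)cc1SCc1ccccc1` gives 17000 nM. Compound 2 `NS(=O)(=O)c1cc(-c2nnc(CN3CCN(c4ccccc4)CC3)o2)c(Cl)cc1SCc1ccccc1` gives 100000 nM, and compound 3 `NS(=O)(=O)c1cc(-c2nnc(CNC(=O)c3ccccc3)o2)c(Cl)cc1SCc1ccccc1` gives 105000 nM. Among these three numbers compound 3 has the highest; its nearest neighbour is compound 2, within the scatter, while compound 1 stands furthest from it, beyond the scatter. Two steps link the measured compounds: a 5.9-fold higher number from compound 1 to compound 2 (0.77 log units; beyond the scatter), and a 1.1-fold higher number from compound 2 to compound 3 (0.02 log units; within the scatter). Compound 4 `NS(=O)(=O)c1cc(-c2nnc(/C=C/c3c(Cl)cccc3Cl)o2)c(Cl)cc1SCc1ccccc1` has not yet been measured in this assay. It differs from compound 3 in one place: 2-(2,6-dichlorophenyl)ethenyl in place of benzamidomethyl on an aromatic carbon. Neither measured step involves the incoming group, so both bear on the expectation only loosely, as changes at the same aromatic carbon that moved the number modestly in one case and not beyond the scatter in the other. On that basis the step of a 1.8-fold lower number from compound 3 to compound 4 (0.24 log units; within the scatter) is expected to be a modest fall in the number, no larger than the measured steps themselves. Compound 4 is therefore estimated at 60000 nM, with a range from 15000 nM to 200000 nM.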

Compound 4, half-maximal inhibitory concentration: 12000 nM
Beside the measured number, compound 4's estimate is 5.0-fold (0.70 log units) above it, outside the stated range (below it).
By their numbers in this assay, from the lowest: compounds 4 and 1 (each within the scatter of the next); then compounds 2 and 3 (each within the scatter of the next).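

In this assay this position responds to a swap of groups that match in size: benzamidomethyl and 2-(2,6-dichlorophenyl)ethenyl each have 10 heavy atoms, one six-membered aromatic ring and one double bond outside aromatic rings, yet the exchange gives an 8.8-fold lower number from compound 3 to compound 4 (0.94 log units; beyond the scatter) and so moves the number beyond the scatter. The earlier compounds shown here showed a number near this level only with the 4-benzylpiperazine group, whereas compound 4 with 12000 nM and compound 1 with 17000 nM lie within the scatter of each other, so a piperazine ring is not needed at this position for such a value. No measurement at hand accounts for this step.

The step exchanges the amide link, the ethenyl link and the two chlorine atoms together, so the compounds shown leave open which of these parts carries it. A 2-phenylethenyl group without the chlorine atoms and a 2-phenylethyl chain at the same aromatic carbon would separate those parts.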